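This account rests on a few compounds, and the source may have more. Where it says the series, first, only, none or still open, it means among the compounds named here.

Compound 1, `Cc1cc(C)c(Oc2cc(Nc3ccc(C#N)cc3)c(N)cc2[N+](=O)[O-])c(C)c1`: 32200 nM
Compound 2, `Cc1cc(C)c(Oc2cc(Nc3ccc(C#N)cc3)c([N+](=O)[O-])cc2[N+](=O)[O-])c(C)c1`: > 59800 nM, a limit
Compound 3, `Cc1cc(C)c(Oc2ccc([N+](=O)[O-])c(Nc3ccc(C#N)cc3)c2)c(C)c1`: > 67000 nM, a limit

Of the compounds shown here, three have so far been tested in an ADME assay on H9 cells (Homo sapiens) for cytotoxicity, read by XTT assay, with a stated time of 6 days; a lower number here means that less compound is tolerated, a higher number that more compound is tolerated. Compound 1 gives 32200 nM, a number. For compound 2 the read-out is not a number but a limit of the assay, > 59800 nM, which is the limit of > 59800 nM in this assay, at which 1 of the 3 values shown sits. For compound 3 the read-out is likewise a limit, > 67000 nM, which is the limit of > 67000 nM in this assay, at which 1 of the 3 values shown sits.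

Two single-point changes connect these compounds. Replacing amino with nitro on an aromatic carbon gives an at least 1.8-fold higher number from compound 1 to compound 2 (0.26 log units; that floor lies within the scatter). Replacing nitro with hydrogen on an aromatic carbon gives a step that the two limits leave unreadable from compound 2 to compound 3.

Compound 4 `Cc1cc(C=O)cc(C)c1Oc1cc(Nc2ccc(C#N)cc2)c([N+](=O)[O-])cc1[N+](=O)[O-]` is the next compound to be measured in this assay. It differs from compound 2 by formyl in place of methyl on an aromatic carbon. Within the data shown here, neither of the two measured steps touches this part of the molecule, so neither bears directly on the change; the one guide is that compound 2 stands at a limit of the assay. A step that the limit leaves unreadable from compound 2 to compound 4 is therefore expected, which is no movement beyond the scatter. Compound 4 is estimated at 60000 nM, with a range from 30000 nM to 120000 nM.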

Compound 4, half-maximal cytotoxic concentration: 57900 nM
Estimate against measurement, compound 4: 1.0-fold (0.02 log units) above, and the stated range covers the measured number.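

Compounds 1, 2 and 3 all carry methyl at this position, para to a large group, so compound 4 gives the first view of a different group there in this assay. Placing formyl there gives an at least 1.0-fold lower number from compound 2 to compound 4 (0.01 log units; that floor lies within the scatter), and compound 4 yields a true number, 57900 nM, which gives this part of the series a firm reading. That step is only a floor, and its real size stays unknown because compound 2 ends at a limit rather than a number: the limit of > 59800 nM in this assay, at which 1 of the 4 values shown sits.

The compounds shown therefore leave open whether formyl truly lowers the tolerated concentration or leaves it essentially unchanged, and whether the same swap would behave alike with the amino group of compound 1 or the hydrogen of compound 3 in place of the nitro group. They also leave open how the position responds to other groups, such as a hydroxymethyl group, a carboxylic acid or an amine, which would show whether the reading for formyl extends to other groups at this position.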